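A few compounds are considered here, and "the series" means these few. Any claim that something is new, unique, unknown or untested is made for them only; others in the source may bear on it.

Compound 1, `COc1ccc(C2=C(c3cc(OC)c(OC)c(OC)c3)C(=O)C(OC(C)=O)C2)cc1OC(C)C`, has been tested in an ADME assay on HT-29 cells (Homo sapiens) for cytotoxicity, read by MTT assay, with a stated time of 72 h; on this read-out higher numbers stand for weaker inhibition and lower numbers for stronger inhibition. In this assay compound 1 gives > 100 ug/mL, which is a limit of the assay and not a number. Compound 2, `COc1ccc(C2=C(c3cc(OC)c(OC)c(OC)c3)C(=O)CC2C)cc1C(=O)O`, gives > 100 ug/mL in this assay, and this too is a limit. Within the data shown here, no two measured compounds differ in one place only, so no measured step is available as a guide. Compound 3, `COc1ccc(C2=C(c3cc(OC)c(OC)c(OC)c3)C(=O)C(OC(C)=O)C2)cc1`, has not yet been measured. It departs from compound 1 by one change, hydrogen in place of isopropoxy on an aromatic carbon, ortho to a methoxy group. With only limits to go on, the size of the effect is very uncertain, but a move toward stronger inhibition is expected, with an estimated at least 2.5-fold lower number from compound 1 to compound 3 (0.39 log units; beyond the scatter). The assay may well report only a limit again. For compound 3 the estimated value is 40 ug/mL, with an expected range from 3 ug/mL to 100 ug/mL.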

Compound 3, half-maximal inhibitory concentration: < 1 ug/mL
Compound 3 was reported as a limit; the forecaster's own chance of this, stated with the estimate: 50%; at least 40-fold (1.60 log units) between middle value and limit.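

Putting hydrogen in place of isopropoxy on an aromatic carbon, ortho to a methoxy group, gives an at least 100-fold lower number from compound 1 to compound 3 (2.00 log units; beyond the scatter) in this assay. The earlier compounds shown here offered no pair differing in one place, so they could not tie the read-out to any single part of the structure; this pair shows that the group on this one carbon can move a compound from one end of the measurable range to the other. The step rests on a limit at each end and not on two numbers, so its true size could be larger still: the limit of > 100 ug/mL in this assay, at which 2 of the 3 values shown sit.

From the compounds shown here alone, whether any group on this carbon weakens inhibition, or only one as large as isopropoxy, remains open. A hydroxyl group or an ethoxy chain at the same place, on the otherwise unchanged core of compound 3, would help to separate these two readings.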